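Trifluoromethyl to methyl on the aromatic ring

A few compounds are considered here, and "the series" means these few. Any claim that something is new, unique, unknown or untested is made for them only; others in the source may bear on it.

Measured in a functional assay on LNCaP cells (Homo sapiens) for cytotoxicity, read by MTT assay, with a stated time of 72 h; on this read-out lower numbers stand for stronger inhibition and higher numbers for weaker inhibition:
- compound 1 `COc1ccc(/C=C/C(=O)/C=C/C2=C(C)CCCC2(C)C)cc1O`: 9900 nM
- compound 2 `CC1=CCCC(C)(C)C1/C=C/C(=O)/C=C/c1cccc(C(F)(F)F)c1`: 1000 nM

Of these two, compound 2 has the lower number, 1000 nM, and the gap to compound 1 lies beyond the scatter. The next compound to be read is compound 3 `CC1=CCCC(C)(C)C1/C=C/C(=O)/C=C/c1cccc(C)c1`, which differs from compound 2 in one place: methyl in place of trifluoromethyl on an aromatic carbon. Among the compounds with values here, no measured pair shows a single change of this kind, so the data do not size this step directly. A modest rise in the number is expected in this assay, possibly not much beyond the scatter. The expected step of a 2.0-fold higher number from compound 2 to compound 3 (0.30 log units; within the scatter) points toward weaker inhibition. For compound 3 the estimated value is 2000 nM, with an expected range of 700 nM to 6000 nM.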

Compound 3, half-maximal inhibitory concentration: 12200 nM
Estimate against measurement, compound 3: 6.1-fold (0.79 log units) below, outside the stated range (above it).
By their numbers in this assay, from the lowest: compound 2; then compounds 1 and 3 (each within the scatter of the next).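

Within the data shown here, replacing trifluoromethyl with methyl gives a 12-fold higher number from compound 2 to compound 3 (1.09 log units; beyond the scatter) in this assay, the first single-change step, and it shows that this substituent on the aromatic ring strongly affects the read-out while the shared core stays fixed. The direction is toward weaker inhibition, even though the two groups match in their counts of hydrogen-bond donors, hydrogen-bond acceptors and net charge, so those counts do not separate compound 2 from compound 3. Nothing measured here accounts for the size of this step.

On these data alone, whether a chlorine atom, a nitrile or an amine at this place would sit nearer compound 2 or compound 3 remains open. Also open, as far as these compounds go, is whether the same exchange would have a similar effect on another aromatic carbon or on another core.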